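The compounds below may be only part of what the source reports. "The series", "measured", "known", "first", "only" and "open" are said of these compounds alone.

Compound 3 `CC(CCNC(=O)c1c(Cl)cncc1Cl)N1CCC(C(Oc2cccc(C(=O)O)n2)c2ccc(C(F)(F)F)cc2)CC1` takes the second highest of the three numbers measured in an ADME assay on PBMC cells (Homo sapiens) for cytotoxicity; a higher number here means that more compound is tolerated, a lower number that less compound is tolerated: compound 3 gives 28700 nM. Its nearest neighbour is compound 1 `Cc1ccnc(OC(c2ccc(C(F)(F)F)cc2)C2CCN(C(C)CCNC(=O)c3c(Cl)cncc3Cl)CC2)c1`, which in this assay gives 33600 nM; the furthest is compound 2 `COC(=O)c1cccc(OC(c2ccc(C(F)(F)F)cc2)C2CCN(C(C)CCNC(=O)c3c(Cl)cncc3Cl)CC2)c1`, which in this assay gives 15200 nM. Compound 4 `CC(CCNC(=O)c1c(Cl)cncc1Cl)N1CCC(C(Oc2ccccc2C#N)c2ccc(C(F)(F)F)cc2)CC1` differs from compound 3 in one place: 2-cyanophenyl in place of 6-carboxypyridin-2-yl on an oxygen on a saturated carbon. Among the compounds with values here, two measured steps bear on this exchange of the group on an oxygen on a saturated carbon: a 1.2-fold lower number from compound 1 to compound 3 (0.07 log units; within the scatter) and a 1.9-fold higher number from compound 2 to compound 3 (0.28 log units; within the scatter); the third such exchange, a 2.2-fold lower number from compound 1 to compound 2 (0.34 log units; beyond the scatter), was modest. Exchanges of this group have moved this assay little, so no step beyond the scatter is expected for compound 4. Compound 4 is expected to give 25000 nM, within 12000 nM to 50000 nM, which means a 1.1-fold lower number from compound 3 to compound 4 (0.06 log units; within the scatter).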

Compound 4, half-maximal cytotoxic concentration: 17000 nM
Estimate against measurement, compound 4: 1.5-fold (0.17 log units) above; the measured number falls inside the stated range.
By their numbers in this assay, from the lowest: compounds 2, 4, 3 and 1 (each within the scatter of the next, the first and the last beyond it).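

The 2-cyanophenyl group, with a ring of carbon only and no hydrogen-bond donor, stays within the scatter of the 6-carboxypyridin-2-yl group in this assay (a 1.7-fold lower number from compound 3 to compound 4 (0.23 log units; within the scatter)) and of the 3-(methoxycarbonyl)phenyl group (a 1.1-fold higher number from compound 2 to compound 4 (0.05 log units; within the scatter)). It also stays within the scatter of the 4-methylpyridin-2-yl group, though only just (a 2.0-fold lower number from compound 1 to compound 4 (0.30 log units; within the scatter)). This position on the oxygen therefore tolerates a nitrile as well as an acid or an ester without a step beyond the scatter.

As far as these compounds go, whether an amine or a longer chain here would move this number further remains open. Nothing shown offers a reason for these small steps.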